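Fluoro in Place of Methoxy in a Toll-like Receptor 9 Antagonist Pair

The source may report more compounds than this note shows. Statements on the series, on what has been measured and on what is new or still open speak of the compounds shown alone.

Compound 1 `COc1ccc(CNc2nc(N3CCN(C4CCCC4)CC3)c3ncn(CCCN4CCCC4)c3n2)cc1` and compound 2 `CCN1CCN(CCCn2cnc3c(N4CCN(CC)CC4)nc(NCc4ccc(OC)cc4)nc32)CC1` share much of their build, but the difference between their cores is not broken down here. In an assay on HEK293 cells for antagonist activity at Toll-like receptor 9 (Homo sapiens), read by spectrophotometry (on this read-out lower numbers stand for stronger inhibition and higher numbers for weaker inhibition), compound 1 gives 240 nM, and compound 2 gives 200 nM. Compound 3 `CCN1CCN(CCCn2cnc3c(N4CCN(CC)CC4)nc(NCc4ccc(F)cc4)nc32)CC1` carries the change fluoro in place of methoxy on an aromatic carbon relative to compound 2, and in this assay compound 3 gives 470 nM, so that a 2.4-fold higher number from compound 2 to compound 3 (0.37 log units; beyond the scatter). Compound 4 `Fc1ccc(CNc2nc(N3CCN(C4CCCC4)CC3)c3ncn(CCCN4CCCC4)c3n2)cc1` carries the same change relative to compound 1, namely (fluoro in place of methoxy on an aromatic carbon), at the same place. Among the measured compounds shown here, the step from compound 1 to compound 4 is expected to be a 2.4-fold higher number from compound 1 to compound 4 (0.38 log units; beyond the scatter) in this assay, because the one measured step of this kind gave a 2.4-fold higher number from compound 2 to compound 3 (0.37 log units; beyond the scatter). Compound 4 is accordingly estimated at 570 nM in this assay, with a likely range from 300 nM to 1100 nM.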

Compound 4, half-maximal inhibitory concentration: 100 nM
Compound 4: middle estimate off by 5.7-fold (0.76 log units), on the high side; the whole stated range lies above it.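

In this assay, the same swap on the core of compound 1 ran opposite to the earlier case, giving a 2.4-fold lower number from compound 1 to compound 4 (0.38 log units; beyond the scatter). The direction of this change therefore did not carry from one core to the other: the same change on two cores in this assay, a 2.4-fold higher number (0.37 log units; beyond the scatter) from compound 2 to compound 3 and a 2.4-fold lower number (0.38 log units; beyond the scatter) from compound 1 to compound 4, 5.6-fold (0.75 log units) apart, beyond the scatter of two such steps. Among the compounds shown here, this does not show why the two cores part ways, and with only one pair on each core, it cannot tell which direction a further core would follow.

From the compounds shown here alone, it remains open which of the parts that differ between the two cores decides the direction. Also open, going by these compounds, is whether chloro or a plain hydrogen in place of the methoxy, on the same aromatic carbon, would split the two cores in the same way.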